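The compounds below may be only part of what the source reports. "The series", "measured", "known", "first", "only" and "open" are said of these compounds alone.

Measured in a functional assay on SK-OV-3 cells (Homo sapiens) for inhibition, read by CCK-8 assay, with a stated time of 70 h; a lower number here means a stronger inhibitor, a higher number a weaker inhibitor:
- compound 1 `c1ccc(COc2ccc(COc3ccc(OCCOCCNC4CCCC4)cc3)cc2)cc1`: 10000 nM
- compound 2 `Nc1cccc(COc2ccc(OCCOCCNC3CCCC3)cc2)c1`: 10800 nM

The reading for compound 2, 10800 nM, lies within the usual scatter of the reading for compound 1, so the two cannot be told apart. Within the data shown here, neither pair of structures differs in just one place, so no clean measured step is available as a guide.

Compound 3 `O=Cc1ccc(COc2ccc(OCCOCCNC3CCCC3)cc2)cc1` has 4-formylphenyl in place of the 3-aminophenyl of compound 2, on a saturated chain carbon bound to an oxygen on an aromatic ring (4-formylphenyl in place of 3-aminophenyl on a saturated chain carbon bound to an oxygen on an aromatic ring). Compound 1 also carries a different group at this end of the molecule and still gives 10000 nM, which suggests only a modest change here. In this assay, the expected step of a 1.2-fold lower number from compound 2 to compound 3 (0.08 log units; within the scatter) stays within the scatter. Compound 3 is estimated at 9000 nM, with an expected range of 4000 nM to 20000 nM.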

Compound 3, half-maximal inhibitory concentration: 45000 nM
The estimate for compound 3 lay 5.0-fold (0.70 log units) below the measured number; the measured number lies above the stated range.
By their numbers in this assay, from the lowest: compounds 1 and 2 (each within the scatter of the next); then compound 3.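

The two earlier compounds hinted that this end of the molecule might tolerate change, but the formyl compound shows otherwise. In this assay, 4-formylphenyl in place of 3-aminophenyl on the saturated chain carbon gives a 4.2-fold higher number from compound 2 to compound 3 (0.62 log units; beyond the scatter), and formyl in place of benzyloxy on an aromatic carbon gives a 4.5-fold higher number from compound 1 to compound 3 (0.65 log units; beyond the scatter), so compound 3 is a weaker inhibitor by both comparisons, and the group carried here does affect the reading. No measurement shown gives a reason for this loss.

The change from 3-aminophenyl to 4-formylphenyl alters both the group and its ring position, so the two effects cannot be separated. A 3-formylphenyl or 4-aminophenyl group at this place would show whether the formyl group itself or its ring position goes with the weaker reading.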